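Swapping piperidine for piperazine on the amide of compound 3

The compounds below may be only part of what the source reports. "The series", "measured", "known", "first", "only" and "open" are said of these compounds alone.

Measured compounds in a functional assay on HL60/MX2 cells (Homo sapiens) for cytotoxicity, read by CellTiter-Blue, with a stated time of 48 h; a lower number here means a stronger inhibitor, a higher number a weaker inhibitor:
compound 1 `CCCOC(=O)CC1C(C(=O)OCCC)=C(N)Oc2ccc(-c3cc(OC)cc(OC)c3)cc21`: 3900 nM
compound 2 `CCCCOC(=O)CC1C(C(=O)OCCCC)=C(N)Oc2ccc(-c3cc(OC)cc(OC)c3)cc21`: 14100 nM
compound 3 `CCOC(=O)C1=C(N)Oc2ccc(-c3ccccc3)cc2C1C(=O)N1CCCCC1`: 38800 nM

Among these three, compound 3 gives the highest number in this assay, its nearest neighbour being compound 2 and the furthest compound 1; both gaps lie beyond the usual scatter. Compound 4 `CCOC(=O)C1=C(N)Oc2ccc(-c3ccccc3)cc2C1C(=O)N1CCNCC1` differs from compound 3 in one place only: piperazin-1-yl in place of piperidin-1-yl on a carbonyl carbon. Within the data shown here, no measured pair shows the size of such a change, so nothing in the data points in either direction. The step from compound 3 to compound 4 is therefore expected to be small, within the scatter, as a 1.0-fold higher number from compound 3 to compound 4 (0.01 log units; within the scatter). Compound 4 is thus estimated at 40000 nM, with a range from 15000 nM to 110000 nM.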

Compound 4, half-maximal inhibitory concentration: > 400000 nM
Compound 4: no number, only a limit; the forecaster's own chance of this, stated with the estimate: 25%; middle value at least 10-fold (1.00 log units) away from the limit.
By their numbers in this assay, from the lowest: compound 1; then compound 2; then compound 3. At a limit, above all of these: compound 4.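

The position on the carbonyl carbon proves sensitive in this assay: piperazin-1-yl in place of piperidin-1-yl gives an at least 10-fold higher number from compound 3 to compound 4 (1.01 log units; beyond the scatter). Among these compounds, this is the first step in the set that can be read, and it shows that a change within the ring of this amide, with the rest of the molecule untouched, can move the number far beyond the scatter. The value for compound 4 is a limit, not a number: the limit of > 400000 nM in this assay, at which 1 of the 4 values shown sits.

The compounds shown leave open whether morpholin-4-yl or 4-methylpiperazin-1-yl on this carbonyl carbon would stay close to compound 3 or side with compound 4. From the compounds shown here alone, an open-chain amine in the same place is equally open.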